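The source may hold more compounds than are shown below. What is called first, only, known or untested is meant among the compounds shown, and "the series" means these compounds.

Measured so far:

Compound 1, `CC1=C(C(=O)Nc2ccc(F)cc2)C(c2ccc([N+](=O)[O-])cc2)N=C(SCc2ccccc2Cl)N1`: 12.4%
Compound 2, `CC1=C(C(=O)Nc2ccc(F)cc2)C(c2ccc([N+](=O)[O-])cc2)N=C(SCc2cccc(Cl)c2)N1`: 11.9%
Compound 3, `CC1=C(C(=O)Nc2ccc([N+](=O)[O-])cc2)C(c2cccc([N+](=O)[O-])c2)N=C(SCc2ccccc2Cl)N1`: 9.3%

All three were tested in a functional assay on the whole organism (artery, strain albino) with Rattus norvegicus as the target, with a stated time of 180 min, at a dose of 10 mg/kg by the oral route; a higher number here means more inhibition at the dose given (going by the name of the read-out), a lower number less inhibition. For the measured compounds named here, the one change that has been tried on a measured pair is 3-chlorophenyl in place of 2-chlorophenyl on a saturated chain carbon bound to a sulfur, and it gave a number 0.5 percentage points lower from compound 1 to compound 2 (within the scatter). Compound 3 carries a different core from compound 1; the difference between the two cores is not broken down here. Compound 4, `CC1=C(C(=O)Nc2ccc([N+](=O)[O-])cc2)C(c2cccc([N+](=O)[O-])c2)N=C(SCc2cccc(Cl)c2)N1`, has not been measured. Going by the values given here, it differs from compound 3 by 3-chlorophenyl in place of 2-chlorophenyl on a saturated chain carbon bound to a sulfur, the same change as the one from compound 1 to compound 2, made at the same place. For compound 4 the expected step is a number 0.3 percentage points lower from compound 3 to compound 4 (within the scatter). That expectation rests on a number 0.5 percentage points lower from compound 1 to compound 2 (within the scatter), which stayed within the usual scatter. Compound 4 is therefore estimated at 9%. The expected range for compound 4 runs from 0% to 19%.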

Compound 4, a percentage reported as inhibition, in the whole organism at one dose (the size of the read-out at that dose, not a potency): 14.9%
Compound 4: middle estimate off by 5.9 percentage points, on the low side; low and high end bracket the measured number.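

Replacing 2-chlorophenyl with 3-chlorophenyl on a saturated chain carbon bound to a sulfur gave a number 5.6 percentage points higher from compound 3 to compound 4 (within the scatter) in this assay. Set beside the same change on the core of compound 1, the two steps cannot be told apart: the same change on two cores in this assay, a number 0.5 percentage points lower (within the scatter) from compound 1 to compound 2 and a number 5.6 percentage points higher (within the scatter) from compound 3 to compound 4, 6.1 percentage points apart, within the scatter of two such steps This gives no sign that the core alters the outcome of the change, but it does not prove that the two steps are truly equal, and neither step shows that the change does anything on either core.

The compounds shown leave open how other groups on the sulfur, such as an unsubstituted benzyl, a methyl or a chain ending in an amine, would read in this assay. They also leave open what this change does on any third core.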